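A few compounds are considered here, and "the series" means these few. Any claim that something is new, unique, unknown or untested is made for them only; others in the source may bear on it.

Measured in a functional assay on a cell-free system (plasma, Oryctolagus cuniculus) for inhibition, with stated times of 5 min, 1 min and 6 min; on this read-out higher numbers stand for weaker inhibition and lower numbers for stronger inhibition:
Compound 1 `CCOC(=O)c1[nH]c(-c2cccc(C#N)c2)nc1C`: > 30000 nM, a limit of the assay.
Compound 2 `CCOC(=O)COn1c(-c2cccc(C#N)c2)nc(C)c1C(=O)OCC`: 6800 nM.

Among the compounds with values here, compound 2 thus holds the only actual number so far. Compound 3 `CCOC(=O)c1c(C)nc(-c2cccc(C#N)c2)n1OCc1ccncc1` differs from it at one place: pyridin-4-yl in place of ethoxycarbonyl on a saturated chain carbon bound to an oxygen on an aromatic ring. Within the data shown here, the only measured step, an at least 4.4-fold lower number from compound 1 to compound 2 (0.64 log units; beyond the scatter), added (ethoxycarbonyl)methoxy in place of hydrogen on an aromatic nitrogen. Among the measured compounds shown here, no measured step replaces ethoxycarbonyl itself, so this step gives only loose guidance and no direction. The expected step, a 1.1-fold lower number from compound 2 to compound 3 (0.05 log units; within the scatter), is estimated to stay within the scatter. Compound 3 is expected at 6000 nM, with an estimated range of 1500 nM to 25000 nM.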

Compound 3, half-maximal inhibitory concentration: 6200 nM
Compound 3: middle estimate off by 1.0-fold (0.01 log units), on the low side; the range from low to high includes it.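

In this assay, pyridin-4-yl in place of ethoxycarbonyl on a saturated chain carbon bound to an oxygen on an aromatic ring gives a 1.1-fold lower number from compound 2 to compound 3 (0.04 log units; within the scatter), so these two groups cannot be told apart at this position. With (pyridin-4-yl)methoxy in place of hydrogen on an aromatic nitrogen there is an at least 4.8-fold lower number from compound 1 to compound 3 (0.68 log units; beyond the scatter), so the lower number seen with compound 2 does not depend on ethoxycarbonyl. Both steps from compound 1 start from a limit: the limit of > 30000 nM in this assay, at which 1 of the 3 values shown sits.

Going by these compounds, whether a carboxylic acid, an amine or a longer chain at this carbon would shift the number remains open.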